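Moving a methoxy group from compound 2 to compound 3

This account rests on a few compounds, and the source may have more. Where it says the series, first, only, none or still open, it means among the compounds named here.

For the measured compounds named here, in an ADME assay on L02 cells (Homo sapiens) for inhibition, read by CCK-8 assay, with a stated time of 48 h (on this read-out higher numbers stand for weaker inhibition of growth and lower numbers for stronger inhibition of growth), compound 1 (`CN1CCN(c2ccc(Nc3ncc(Cl)c(NCc4ccccc4)n3)nc2)CC1`) gives 20300 nM and compound 2 (`COc1ccc(CNc2nc(Nc3ccc(N4CCN(C)CC4)cn3)ncc2Cl)cc1`) gives 12900 nM as the lower of only two numbers. The gap between them is small: the data show a 1.6-fold lower number from compound 1 to compound 2 (0.20 log units; within the scatter) for methoxy in place of hydrogen on an aromatic carbon.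

Compound 3 (`COc1cccc(CNc2nc(Nc3ccc(N4CCN(C)CC4)cn3)ncc2Cl)c1`) has the same atoms as compound 2, joined differently (3-methoxyphenyl in place of 4-methoxyphenyl on a saturated chain carbon bound to a nitrogen on an aromatic ring), with 3-methoxyphenyl in place of 4-methoxyphenyl on a saturated chain carbon bound to a nitrogen on an aromatic ring. Going by the values given here, no measured step moves a group in this way, so the closest guide is the step to compound 2, a 1.6-fold lower number from compound 1 to compound 2 (0.20 log units; within the scatter) in this assay from adding the methoxy itself. Moving that group is therefore expected to cause no step beyond the scatter. The estimated step is a 1.1-fold higher number from compound 2 to compound 3 (0.04 log units; within the scatter) and stays within that scatter. Compound 3 is expected at 14000 nM with 7000 nM to 28000 nM as the estimated range.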

Compound 3, concentration for 50% growth inhibition: 16200 nM
Compound 3: middle estimate off by 1.2-fold (0.06 log units), on the low side; the range from low to high includes it.
By their numbers in this assay, from the lowest: compounds 2, 3 and 1 (each within the scatter of the next).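

In this assay, moving the methoxy from the 4-methoxyphenyl to the 3-methoxyphenyl arrangement gives a 1.3-fold higher number from compound 2 to compound 3 (0.10 log units; within the scatter), so the two placements cannot be told apart on this read-out. Methoxy in place of hydrogen at the new ring position gives a 1.3-fold lower number from compound 1 to compound 3 (0.10 log units; within the scatter), so neither placement separates from the compound without methoxy, and the earlier small step now holds for a second ring position as well. Nothing available gives a reason for these small steps.

On these data alone, it remains open whether a different group on the same aromatic ring, such as an amine, a carboxylic acid or a longer chain like ethoxy, would give a step beyond the scatter. The three compounds also share the same core, so they say nothing about changes elsewhere in the structure.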